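A nitro group on the benzyl arm of compound 2

The compounds below may be only part of what the source reports. "The series", "measured", "known", "first", "only" and "open" are said of these compounds alone.

Going by the values given here, compound 2 `Cc1cccc(Cn2cc(CNC(=O)c3cnc(Nc4ccc(C#N)cc4)cc3Oc3c(C)cc(C)cc3C)nn2)c1` holds the only plain number in this set. In an ADME assay on MT4 cells (Homo sapiens) for cytotoxicity, read by MTT assay, with a stated time of 5 days (on this read-out higher numbers stand for lower toxicity in this test and lower numbers for higher toxicity in this test), compound 2 gives 114000 nM. Compound 1 `Cc1cc(C)c(Oc2cc(Nc3ccc(C#N)cc3)ncc2C(=O)NCc2cn(Cc3ccccc3F)nn2)c(C)c1` reaches only a limit of the assay, giving > 222000 nM in this assay. Compound 3 `Cc1cc(C)c(Oc2cc(Nc3ccc(C#N)cc3)ncc2C(=O)NCc2cn(Cc3ccccc3Cl)nn2)c(C)c1` likewise stops at a limit, giving >= 188000 nM in this assay. Compound 4 `Cc1cc(C)c(Oc2cc(Nc3ccc(C#N)cc3)ncc2C(=O)NCc2cn(Cc3ccc([N+](=O)[O-])cc3)nn2)c(C)c1` has not yet been measured; it differs from compound 2 in that (4-nitrophenyl in place of 3-methylphenyl on a saturated chain carbon bound to an aromatic nitrogen).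

Among the compounds with values here, two measured steps bear on this change, both swaps of the aryl group on the saturated chain carbon bound to an aromatic nitrogen. The step of an at least 1.9-fold lower number from compound 1 to compound 2 (0.28 log units; that floor lies within the scatter) and the step of an at least 1.6-fold higher number from compound 2 to compound 3 (0.21 log units; that floor lies within the scatter) are each bounded by a limit, one by the limit of > 222000 nM in this assay, at which 1 of the 3 values shown sits, and the other by the limit of >= 188000 nM in this assay, at which 1 of the 3 values shown sits, so their true sizes are not fixed, and their floors lie within the scatter. The step that the two limits leave unreadable from compound 1 to compound 3 adds nothing readable. Nothing among these three compounds shows that varying the aryl group moves the read-out beyond scatter, so compound 4 is expected to sit close to compound 2, possibly again at a limit. The step expected here is a 1.3-fold higher number from compound 2 to compound 4 (0.12 log units; within the scatter). For compound 4 the estimate is 150000 nM, ranging from 70000 nM to 300000 nM.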

Compound 4, half-maximal cytotoxic concentration: >= 139000 nM
Compound 4: only a limit was reported (the forecaster's own chance of this, stated with the estimate: 50%); the middle value lies beyond the limit too.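

Compound 4 stops at a limit in this assay and so gives no plain number, the same outcome as compound 1 and compound 3: the limit of >= 139000 nM in this assay, at which 1 of the 4 values shown sits.
Replacing 3-methylphenyl with 4-nitrophenyl on the saturated chain carbon bound to an aromatic nitrogen gives an at least 1.2-fold higher number from compound 2 to compound 4 (0.08 log units; that floor lies within the scatter), so a group with nitrogen and oxygen atoms and two hydrogen-bond acceptors, unlike the halogen and methyl groups on the earlier aryl rings, also produces no step shown to lie beyond the scatter at this place.
The steps from compound 1 and compound 3 to compound 4 cannot be read, since limits stand at both ends of each, which means the 4-nitrophenyl group cannot be ranked against 2-fluorophenyl or 2-chlorophenyl.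

Going by these compounds alone, how far compound 4 truly lies from compound 2 remains open, as only a floor is available for that step, and no compound here shows a group at this place that moves the read-out beyond the scatter. Also open, as far as these compounds go, is what an amine or a carboxylic acid on the aryl ring, or a longer chain in place of the benzyl arm, would give in this assay.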